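The compounds below may be only part of what the source reports. "The series", "measured", "known", "first", "only" and "open" are said of these compounds alone.

Of the compounds shown here, two built on one shared core have been tested in a functional assay on Hs-578T cells (Homo sapiens) for inhibition, read by sulforhodamine B assay, with a stated time of 48 h; a lower number here means a stronger inhibitor of growth, a higher number a weaker inhibitor of growth. Compound 1 `C=C1CC[C@@H]2[C@](C)(COC(C)=O)[C@H](OC(C)=O)CC[C@@]2(C)[C@H]1CC(Nc1ccc(S(=O)(=O)Nc2nccc(C)n2)cc1)C1=CCOC1=O` carries a 4-methylpyrimidin-2-yl group on the sulfonamide nitrogen, and in this assay compound 1 gives 43000 nM. Compound 2 `C=C1CC[C@@H]2[C@](C)(COC(C)=O)[C@H](OC(C)=O)CC[C@@]2(C)[C@H]1CC(Nc1ccc(S(=O)(=O)Nc2nccs2)cc1)C1=CCOC1=O` carries a 1,3-thiazol-2-yl group at that position instead, and in this assay compound 2 gives 60400 nM. Compound 2 has the higher of the two numbers, but the gap, a 1.4-fold higher number from compound 1 to compound 2 (0.15 log units; within the scatter), lies within the scatter, so the two compounds cannot be separated.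

Compound 3 `C=C1CC[C@@H]2[C@](C)(COC(C)=O)[C@H](OC(C)=O)CC[C@@]2(C)[C@H]1CC(Nc1ccc(S(=O)(=O)Nc2ccc(Cl)nn2)cc1)C1=CCOC1=O` is not yet measured. The change from compound 2 is 6-chloropyridazin-3-yl in place of 1,3-thiazol-2-yl on a sulfonamide nitrogen. Going by the values given here, the one step that bears on it, a 1.4-fold higher number from compound 1 to compound 2 (0.15 log units; within the scatter), also swapped the group on the sulfonamide nitrogen and produced nothing beyond the scatter. Accordingly, the step to compound 3 is expected to be about a 1.1-fold lower number from compound 2 to compound 3 (0.04 log units; within the scatter), with no change beyond the scatter. The estimated value for compound 3 is 55000 nM, within a range from 25000 nM to 120000 nM.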

Compound 3, concentration for total growth inhibition: > 100000 nM
Compound 3 gave a limit, no number; the forecaster's own chance of this, stated with the estimate: 10%; middle value at least 1.8-fold (0.25 log units) away from the limit.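

The group on the sulfonamide nitrogen can shift the reading in this assay after all: putting 6-chloropyridazin-3-yl there gives an at least 2.3-fold higher number from compound 1 to compound 3 (0.36 log units; beyond the scatter), a step beyond the scatter, whereas the swap between the two earlier compounds produced none. The second step, an at least 1.6-fold higher number from compound 2 to compound 3 (0.21 log units; that floor lies within the scatter), has only a floor that lies within the scatter, so the true gap may be larger, but this floor alone does not separate the pair. The reading for compound 3 is a limit of the assay and not a number: the limit of > 100000 nM in this assay, at which 1 of the 3 values shown sits.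

On these data alone, whether the chlorine itself matters, as against a plain pyridazin-3-yl group, stays open. Also open, as far as these compounds go, is how a phenyl ring or a simple methyl group on the sulfonamide nitrogen would read in this assay.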